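Two Fluorines in Place of One: Compound 3 to Compound 4

This account rests on a few compounds, and the source may have more. Where it says the series, first, only, none or still open, it means among the compounds named here.

Compound 3 `O=C(O)c1ccccc1-c1ccc(CCc2ncc(Cc3ccc(F)cc3)[nH]2)cc1` shows the highest number of the three measured compounds in an in vitro functional assay on cells for agonist activity at Bombesin receptor subtype-3 (Mus musculus), read by luminescence and calcium flux (a higher number here means that more compound is needed for the effect, a lower number that less compound is needed), at 50 nM. Compound 1 `O=C(O)c1ccccc1-c1ccc(CCc2ncc(CC3CCCCC3)[nH]2)cc1` gives 7.3 nM and compound 2 `N#Cc1cccc(Cc2cnc(CCc3ccc(-c4ccccc4C(=O)O)cc3)[nH]2)c1` gives 20 nM; the steps are a 6.8-fold higher number from compound 1 to compound 3 (0.84 log units; beyond the scatter) and a 2.5-fold higher number from compound 2 to compound 3 (0.40 log units; beyond the scatter), while a 2.7-fold higher number from compound 1 to compound 2 (0.44 log units; beyond the scatter) separates the two lower values. Compound 4 `O=C(O)c1ccccc1-c1ccc(CCc2ncc(Cc3cccc(F)c3F)[nH]2)cc1` differs from compound 3 by 2,3-difluorophenyl in place of 4-fluorophenyl on a saturated chain carbon bound to an aromatic carbon. All three measured steps change the group at this same place, each shifting the number modestly, but none alters only the fluorine pattern of a phenyl, so the direction of this step is not indicated by the data. A modest step in either direction, or none beyond the scatter, is expected, no change at the digits printed from compound 3 to compound 4 (within the scatter). Compound 4 is estimated at 50 nM, with a likely range from 15 nM to 160 nM.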

Compound 4, half-maximal effective concentration: 8 nM
For compound 4 the middle estimate is 6.3-fold (0.80 log units) above the measured one; measured number below the stated range.
By their numbers in this assay, from the lowest: compounds 1 and 4 (each within the scatter of the next); then compound 2; then compound 3.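

In this assay, among these compounds, the fluorine pattern alone moves the number at this place, with a 6.3-fold lower number from compound 3 to compound 4 (0.80 log units; beyond the scatter) as the first step between two fluorinated phenyls. The 2,3-difluorophenyl group also gives a 2.5-fold lower number from compound 2 to compound 4 (0.40 log units; beyond the scatter) and a 1.1-fold higher number from compound 1 to compound 4 (0.04 log units; within the scatter) so a phenyl here need not give a higher number than cyclohexyl, although compounds 2 and 3 do. Nothing given here bears on the cause of this shift. As far as these compounds go, whether both fluorines are needed stays open, as does how 2,3-dichlorophenyl or a methoxyphenyl would read at this place.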